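A few compounds are considered here, and "the series" means these few. Any claim that something is new, unique, unknown or untested is made for them only; others in the source may bear on it.

Compound 1 `COc1ccccc1-c1cc(C2CCN(C)C2)ccc1Cl` is the starting point, and in an assay on isolated protein for binding affinity to 5-hydroxytryptamine receptor 1E (Homo sapiens) (a higher number here means a weaker inhibitor, a lower number a stronger inhibitor), compound 1 gives 4100 nM. Among the values on hand it sits level with compound 3 `COc1ccccc1-c1cc(CN(C)C)ccc1Cl`, which in this assay gives 4100 nM; the step of no change at the digits printed from compound 1 to compound 3 (within the scatter) lies within the scatter. Compound 2 `CCNCc1ccc(Cl)c(-c2ccccc2OC)c1` is different: in this assay compound 2 gives only > 10000 nM, which is a limit of the assay and not a number (the limit of > 10000 nM in this assay, at which 1 of the 3 values shown sits). The steps of an at least 2.4-fold higher number from compound 1 to compound 2 (0.38 log units; beyond the scatter) and an at least 2.4-fold lower number from compound 2 to compound 3 (0.38 log units; beyond the scatter) therefore both reach beyond the scatter, and both point the same way: the (ethylamino)methyl group lands at a weaker level than either the ring of compound 1 or the (dimethylamino)methyl group of compound 3.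

Compound 4 `CCCCNCc1ccc(Cl)c(-c2ccccc2OC)c1` is not yet measured. It differs from compound 1 in one place: (butylamino)methyl in place of 1-methylpyrrolidin-3-yl on an aromatic carbon. Like compound 2, it carries a secondary amine on the chain, so the step that bears on it most closely is an at least 2.4-fold higher number from compound 1 to compound 2 (0.38 log units; beyond the scatter). A weakening of at least that size is expected for compound 4 in this assay, and a limit rather than a number is quite possible. Compound 4 is accordingly estimated at 12000 nM, in the range 5000 nM to 30000 nM. That estimate means a step of a 2.9-fold higher number from compound 1 to compound 4 (0.47 log units; beyond the scatter).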

Compound 4, inhibition constant: > 10000 nM
Compound 4 ended at the assay's limit (the forecaster's own chance of this, stated with the estimate: 60%); the middle value is on the limit's open side.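

In this assay compound 4, like compound 2, ends at a limit of the assay and not at a number: the limit of > 10000 nM in this assay, at which 2 of the 4 values shown sit.

The steps of an at least 2.4-fold higher number from compound 1 to compound 4 (0.38 log units; beyond the scatter) and an at least 2.4-fold higher number from compound 3 to compound 4 (0.38 log units; beyond the scatter) both reach beyond the scatter, so at this position, para to the chloro group, the weak result is no longer tied to the ethyl group alone. Among the four compounds shown, the two secondary amines sit at the limit and the two tertiary amines do not, with no compound going against this, and the change from 1-methylpyrrolidin-3-yl to (butylamino)methyl leaves the count of heavy atoms as it was. The step between compound 2 and compound 4 cannot be read, so ethyl and butyl cannot be put in order.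

The compounds shown leave open whether the secondary amine itself goes with the weaker result, which a primary aminomethyl group or a (methylamino)methyl group at this position would test. They also leave open whether a tertiary amine with longer chains, such as (diethylamino)methyl, would stay level with compound 3 at 4100 nM.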